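The compounds below may be only part of what the source reports. "The series", "measured", "known", "first", "only" and "open" are said of these compounds alone.

Measured in a functional assay on the whole organism (strain Wistar) for inhibition, with Rattus norvegicus as the target, read by paw edema, with stated times of 30 min and 60 min, at a dose of 50 mg/kg by the oral route; on this read-out lower numbers stand for less inhibition and higher numbers for more inhibition at the one dose given (going by the name of the read-out):
compound 1 `CCC(=O)N1N=C(c2ccc(F)cc2)CC1c1cn(-c2ccccc2)nc1-c1ccc(Cl)c(Cl)c1`, 63.4%
compound 2 `Clc1ccc(C2=NNC(c3cn(-c4ccccc4)nc3-c3ccc(Cl)c(Cl)c3)C2)cc1`, 45.8%
compound 3 `Clc1ccc(C2=NN(c3ccccc3)C(c3cn(-c4ccccc4)nc3-c3ccc(Cl)c(Cl)c3)C2)cc1`, 53.4%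

Compound 3 stands second highest of the three numbers in this assay, with compound 2 nearest, and compound 1 furthest, though both gaps are within the scatter. Among the compounds with values here, the one single-point step in hand, a number 7.6 percentage points higher from compound 2 to compound 3 (within the scatter), concerns a substituent on the ring nitrogen but not the group entering here.

Compound 4 `CCC(=O)N1N=C(c2ccc(Cl)cc2)CC1c1cn(-c2ccccc2)nc1-c1ccc(Cl)c(Cl)c1` carries the change (propanoyl in place of phenyl on an amine nitrogen in a ring). Within the data shown here, no measured step shows propanoyl in place of phenyl on this nitrogen. Compound 1, which bears propanoyl on the same nitrogen, gives 63.4%, and that is the closest guide. For compound 4 the expected step is therefore a number 6.6 percentage points higher from compound 3 to compound 4 (within the scatter), not beyond the scatter. Compound 4 is thus estimated at 60%, in the range 45% to 75%.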

Compound 4, a percentage reported as inhibition, in the whole organism at one dose (the size of the read-out at that dose, not a potency): 61.1%
Estimate against measurement, compound 4: 1.1 percentage points below, and the stated range covers the measured number.
By their numbers in this assay, from the lowest: compounds 2, 3, 4 and 1 (each within the scatter of the next, the first and the last beyond it).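

In this assay, within the data shown here, propanoyl on the amine nitrogen in the ring gives a number 15.3 percentage points higher from compound 2 to compound 4 (beyond the scatter), the first step in this set beyond the scatter, whereas phenyl on that nitrogen gives a number 7.6 percentage points higher from compound 2 to compound 3 (within the scatter). Propanoyl and phenyl are not separated, with a number 7.7 percentage points higher from compound 3 to compound 4 (within the scatter). With propanoyl in place, chloro in place of fluoro on an aromatic carbon gives a number 2.3 percentage points lower from compound 1 to compound 4 (within the scatter), so these two halogens are not separated either.

From the compounds shown here alone, whether a longer acyl chain such as butanoyl, or an acetyl group, would fall within the scatter of propanoyl remains open. Nothing available bears on the reason for these steps.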